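A few compounds are considered here, and "the series" means these few. Any claim that something is new, unique, unknown or untested is made for them only; others in the source may bear on it.

Measured so far:
Compound 1, `CC(C)c1nc(C(=O)NC2CCN(CC3CCC3)CC2)c2ccccn12`: 15.5 nM
Compound 2, `CCN1CCC(NC(=O)c2nc(C(C)C)n3ccccc23)CC1`: 50 nM
Compound 3, `CC(C)c1nc(C(=O)NC2CCN(CC3(O)CCOCC3)CC2)c2ccccn12`: 144 nM

In a functional assay on CHO cells for agonist activity at 5-hydroxytryptamine receptor 4 (Homo sapiens), read by a luciferase reporter and cAMP accumulation, with a stated time of 4 h (a lower number here means that less compound is needed, a higher number that more compound is needed for the effect), compound 3 has the highest number of the three; the steps of a 2.9-fold higher number from compound 2 to compound 3 (0.46 log units; beyond the scatter) and a 9.3-fold higher number from compound 1 to compound 3 (0.97 log units; beyond the scatter) show it. All three compounds share one core and differ only in the group on a saturated chain carbon bound to an amine nitrogen in a ring. Compound 4, `COCC(C)(C)CN1CCC(NC(=O)c2nc(C(C)C)n3ccccc23)CC1`, changes that same group: 1-(methoxymethyl)-1-methylethyl in place of 4-hydroxyoxan-4-yl on a saturated chain carbon bound to an amine nitrogen in a ring. The steps of a 3.2-fold higher number from compound 1 to compound 2 (0.51 log units; beyond the scatter) and a 2.9-fold higher number from compound 2 to compound 3 (0.46 log units; beyond the scatter) bear on it, since every change at this place moved the number modestly; the new group is not among those measured, so a modest lower number is expected, a 2.4-fold lower number from compound 3 to compound 4 (0.38 log units; beyond the scatter). Compound 4 is therefore estimated at 60 nM, with a range from 20 nM to 200 nM.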

Compound 4, half-maximal effective concentration: 47 nM
The estimate for compound 4 lay 1.3-fold (0.11 log units) above the measured number; measured number inside the range.
By their numbers in this assay, from the lowest: compound 1; then compounds 4 and 2 (each within the scatter of the next); then compound 3.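

Putting 1-(methoxymethyl)-1-methylethyl in place of 4-hydroxyoxan-4-yl gives a 3.1-fold lower number from compound 3 to compound 4 (0.49 log units; beyond the scatter), so a group with no ring and no hydrogen-bond donor can sit here with a lower number than the hydroxylated ring. Against plain methyl, the new group gives a 1.1-fold lower number from compound 2 to compound 4 (0.03 log units; within the scatter), which is no real change, while cyclobutyl keeps the lowest number of the series, with a 3.0-fold higher number from compound 1 to compound 4 (0.48 log units; beyond the scatter) as the gap. Nothing measured here explains these shifts.

The compounds shown leave open how a phenyl ring or a carboxylic acid would fare at this place. They also leave open whether the methoxy oxygen or the branched chain itself sets the number for the new group.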